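Sulfonate acrylamides on leukemic cells: methoxy against nitro

The compounds below may be only part of what the source reports. "The series", "measured", "known", "first", "only" and "open" are said of these compounds alone.

Measured compounds in a functional assay on RS4-11 cells (Homo sapiens) for inhibition, read by CCK-8 assay, with a stated time of 48 h, tested at 20 uM; on this read-out higher numbers stand for more inhibition of growth at the one concentration tested and lower numbers for less inhibition of growth:
compound 1 `COc1ccc(S(=O)(=O)Oc2ccccc2/C=C(\C#N)C(=O)Nc2nnc(Cc3cccc4ccccc34)s2)cc1`: 78%
compound 2 `N#C/C(=C\c1ccccc1OS(=O)(=O)c1ccc([N+](=O)[O-])cc1)C(=O)Nc1nnc(Cc2cccc3ccccc23)s1`: 58%
compound 3 `COc1ccc(S(=O)(=O)Oc2ccccc2/C=C(\C#N)C(=O)Nc2nnc(Cc3cccc(F)c3)s2)cc1`: 74%

The three measured compounds share one core and differ at two places. Compound 1 and compound 2 differ in the group on the sulfonyl-bearing ring, (nitro in place of methoxy on an aromatic carbon), and this change gave a number 20 percentage points lower from compound 1 to compound 2 (beyond the scatter). Compound 1 and compound 3 differ in the group carried on the thiadiazole side, (3-fluorophenyl in place of naphthalen-1-yl on a saturated chain carbon bound to an aromatic carbon), which gave a number 4 percentage points lower from compound 1 to compound 3 (within the scatter); compound 1 and compound 3 therefore cannot be told apart on this read-out.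

Compound 4 `N#C/C(=C\c1ccccc1OS(=O)(=O)c1ccc([N+](=O)[O-])cc1)C(=O)Nc1nnc(Cc2cccc(F)c2)s1` has not yet been measured. Among the compounds with values here, it differs from compound 3 by nitro in place of methoxy on an aromatic carbon, the same change as the one from compound 1 to compound 2, made on the same place and against the other of the two side groups. Since the other change, from compound 1 to compound 3, left the read-out where it was, the step from compound 3 to compound 4 is expected to repeat the size seen from compound 1 to compound 2, about a number 20 percentage points lower from compound 3 to compound 4 (beyond the scatter) in this assay. For compound 4 the estimate in this assay is 54%, with the likely range from 40% to 67%, resting on the value of compound 3, 74%, and on the step of a number 20 percentage points lower from compound 1 to compound 2 (beyond the scatter).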

Compound 4, percent growth inhibition at one concentration: 65%
Estimate against measurement, compound 4: 11 percentage points below, within the range that was stated.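

In this assay, nitro in place of methoxy on the core of compound 3 gave a number 9 percentage points lower from compound 3 to compound 4 (within the scatter), and this step does not separate from the earlier one: the same change on two cores in this assay, a number 20 percentage points lower (beyond the scatter) from compound 1 to compound 2 and a number 9 percentage points lower (within the scatter) from compound 3 to compound 4, 11 percentage points apart, within the scatter of two such steps

The side-group change, 3-fluorophenyl in place of naphthalen-1-yl, on the nitro-bearing core gave a number 7 percentage points higher from compound 2 to compound 4 (within the scatter), and it likewise matches its earlier counterpart: the same change on two cores in this assay, a number 4 percentage points lower (within the scatter) from compound 1 to compound 3 and a number 7 percentage points higher (within the scatter) from compound 2 to compound 4, 11 percentage points apart, within the scatter of two such steps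

Within the data shown here, the two cores can therefore be treated as sharing one nitro-for-methoxy step and one side-group step, but the size of the nitro-for-methoxy step remains loosely fixed, since only the step on the core of compound 1 lies beyond the scatter, and two cores do not show that it would carry to other side groups.

As far as these compounds go, whether an amine or a carboxylic acid in place of methoxy or nitro on the sulfonyl-bearing ring would read with compound 3 or with compound 4 remains open. Also open, from the compounds shown here alone, is whether a longer chain on the thiadiazole side would leave the read-out where these two side groups put it, and a single concentration gives no view of how these compounds would compare across a range of concentrations.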